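Compound 3: an untested replacement of the aglycone

The source may report more compounds than this note shows. Statements on the series, on what has been measured and on what is new or still open speak of the compounds shown alone.

Measured so far:
Compound 1, `CC1=CC[C@@H](C(C)(C)O[C@@H]2O[C@H](COC(=O)c3cc(O)c(O)c(O)c3)[C@@H](O)[C@H](O)[C@H]2O)CC1`: 95.4%
Compound 2, `CC1=CC[C@H](C(C)(C)O[C@@H]2O[C@H](COC(=O)c3cc(O)c(O)c(O)c3)[C@@H](O)[C@H](O)[C@H]2O)CC1`: 95.3%

In a functional assay, read by spectrophotometry, with a stated time of 30 min, tested at 80 uM (a lower number here means a weaker effect, a higher number a stronger effect of the compound at the concentration tested), compound 1 gives 95.4%. In this assay compound 2 gives 95.3%. These two compounds share every atom and bond and are set apart only by the drawn configuration at one saturated ring carbon (the fact that compounds 1 and 2 differ only in the configuration as drawn); the step of a number 0.1 percentage points lower from compound 1 to compound 2 (within the scatter) lies within the scatter, so the flip of that centre leaves the read-out unchanged. Of the two numbers, that of compound 2 is nominally the lower, but the gap to compound 1 is within the scatter, and the two cannot be ranked.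

Compound 3, `C=CCc1ccc(O[C@@H]2O[C@H](COC(=O)c3cc(O)c(O)c(O)c3)[C@@H](O)[C@H](O)[C@H]2O)c(OC)c1`, takes a different route: 4-allyl-2-methoxyphenyl in place of 1-methyl-1-(4-methylcyclohex-3-en-1-yl)ethyl on an oxygen on a saturated carbon. For the measured compounds named here, no measured step touches this part of the molecule, since the only step in hand is a change of configuration, so there is no measured guide to the size or direction of the effect in this assay. Compound 3 is therefore expected to give 85%, with a range from 50% to 100%, which means an estimated step of a number 10.3 percentage points lower from compound 2 to compound 3 (beyond the scatter).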

Compound 3, a percentage reported as activity, at one concentration (the size of the read-out at that concentration, not a potency): 95.7%
For compound 3 the middle estimate is 10.7 percentage points below the measured one; low and high end bracket the measured number.
By their numbers in this assay, from the lowest: compounds 2, 1 and 3 (each within the scatter of the next).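

In this assay, putting 4-allyl-2-methoxyphenyl in place of 1-methyl-1-(4-methylcyclohex-3-en-1-yl)ethyl gives a number 0.4 percentage points higher from compound 2 to compound 3 (within the scatter) and likewise a number 0.3 percentage points higher from compound 1 to compound 3 (within the scatter). The earlier compounds shown here showed only that the configuration at one saturated ring carbon could be flipped with no readable difference, whereas this position, on an oxygen on a saturated carbon, now also takes a six-membered aromatic ring bearing a hydrogen-bond acceptor in place of a non-aromatic carbon ring, again with no readable difference. Nothing at hand explains why these two quite different groups give read-outs that cannot be told apart.

The compounds shown leave open whether a group of another kind on this oxygen, such as an amine, a carboxylic acid or a longer carbon chain, would give a similar read-out. As far as these compounds go, the read-out is also the size of the effect at one concentration and not a potency, so it remains open whether these three compounds would still match at lower concentrations.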